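Replacing the Cyclohexyl of Compound 2 with an Open Chain

The source may report more compounds than this note shows. Statements on the series, on what has been measured and on what is new or still open speak of the compounds shown alone.

In an ADME assay on Vero cells (Chlorocebus sabaeus) for cytotoxicity, read by CellTiter-Glo, with a stated time of 72 h (a higher number here means that more compound is tolerated, a lower number that less compound is tolerated), compound 2 `[O-][n+]1nc(NC2CCCCC2)[n+]([O-])c2ccc(F)cc21` gives < 2.5 ug/mL, which is a limit and not a number. Compound 1 `[O-][n+]1nc(NC2CC2)[n+]([O-])c2ccc(F)cc21` gives 1.3 ug/mL. For the measured compounds named here, the only measured step, a step that the limit leaves unreadable from compound 1 to compound 2, therefore has no readable size. Compound 3 `COCC(C)Nc1n[n+]([O-])c2cc(F)ccc2[n+]1[O-]` carries 1-(methoxymethyl)ethyl in place of cyclohexyl on a nitrogen on an aromatic ring. Going by the values given here, the one firm number nearby is compound 1 at 1.3 ug/mL, so no step beyond the scatter is expected in this assay. The expected change is a step that the limit leaves unreadable from compound 2 to compound 3. For compound 3 the estimated value is 2 ug/mL, within a range from 0.7 ug/mL to 5 ug/mL.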

Compound 3, half-maximal cytotoxic concentration: 6.3 ug/mL
Compound 3: middle estimate off by 3.2-fold (0.50 log units), on the low side; measured number above the stated range.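

In this assay, the group on this nitrogen clearly changes how much compound is tolerated: 1-(methoxymethyl)ethyl in place of cyclohexyl gives an at least 2.5-fold higher number from compound 2 to compound 3 (0.40 log units; beyond the scatter), and in place of cyclopropyl it gives a 4.8-fold higher number from compound 1 to compound 3 (0.69 log units; beyond the scatter). Both steps lie beyond the scatter, so the open chain is better tolerated than either ring shown. The first step has only a lower bound, as the value of compound 2 is a limit and not a number: the limit of < 2.5 ug/mL in this assay, at which 1 of the 3 values shown sits.

As far as these compounds go, whether the oxygen of the chain or the loss of the ring matters remains open. A plain butyl chain on the same nitrogen would separate the two.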